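From Bromo to Nitro on One Aromatic Carbon

This account rests on a few compounds, and the source may have more. Where it says the series, first, only, none or still open, it means among the compounds named here.

In a functional assay on A549 cells (Homo sapiens) for inhibition, read by MTT assay, with a stated time of 48 h (on this read-out lower numbers stand for stronger inhibition and higher numbers for weaker inhibition), compound 1 `Brc1ccc2[nH]cc(C(c3ccccc3)c3c[nH]c4ccc(Br)cc34)c2c1` gives 7500 nM, and compound 2 `Brc1ccc(C(c2c[nH]c3ccc(Br)cc23)c2c[nH]c3ccc(Br)cc23)cc1` gives 5600 nM. Compound 2 therefore stands level with compound 1, as the step of a 1.3-fold lower number from compound 1 to compound 2 (0.13 log units; within the scatter) lies within the scatter. That step puts bromo in place of hydrogen on an aromatic carbon. Compound 3 `O=[N+]([O-])c1ccc(C(c2c[nH]c3ccc(Br)cc23)c2c[nH]c3ccc(Br)cc23)cc1` carries nitro in place of bromo on an aromatic carbon, para to a large group: nitro in place of bromo on an aromatic carbon. For the measured compounds named here, no measured compound yet holds a nitro group, so the data offer no direction for this change. Going by the values given here, the only guide is the small step of a 1.3-fold lower number from compound 1 to compound 2 (0.13 log units; within the scatter), so no shift beyond the scatter is expected in this assay. The expected step is a 1.1-fold lower number from compound 2 to compound 3 (0.05 log units; within the scatter). For compound 3 the estimated value is 5000 nM, with an expected range of 1800 nM to 15000 nM.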

Compound 3, half-maximal inhibitory concentration: 5500 nM
Compound 3: middle estimate off by 1.1-fold (0.04 log units), on the low side; low and high end bracket the measured number.
By their numbers in this assay, from the lowest: compounds 3, 2 and 1 (each within the scatter of the next).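

In this assay, exchanging 4-bromophenyl for 4-nitrophenyl leaves the number essentially in place (a 1.0-fold lower number from compound 2 to compound 3 (0.01 log units; within the scatter)), even though nitro brings more heavy atoms than bromo and adds hydrogen-bond acceptors. The comparison with the unsubstituted ring gives the same picture (a 1.4-fold lower number from compound 1 to compound 3 (0.13 log units; within the scatter)), so hydrogen, bromo and nitro on this aromatic carbon all stand level within the scatter. Nothing available alongside these numbers helps to explain this flat result.

As far as these compounds go, whether an amine, a carboxylic acid or a longer chain such as butyl on this aromatic carbon would move the number beyond the scatter remains open. Every compound shown also keeps the bromo groups on the shared core, so what changing them would do remains open too.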